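This account rests on a few compounds, and the source may have more. Where it says the series, first, only, none or still open, it means among the compounds named here.

Compound 1 `O=C1C(O)=C(C(c2ccc(F)cc2)c2c[nH]c3ccccc23)C(=O)c2ccccc21` is the reference point; in a toxicity assay (Homo sapiens) for cytotoxicity, read by MTT assay, with a stated time of 48 h (on this read-out higher numbers stand for weaker inhibition and lower numbers for stronger inhibition), compound 1 gives 65200 nM. Compound 3 `COc1cccc(C(C2=C(O)C(=O)c3ccccc3C2=O)c2c[nH]c3ccccc23)c1` gives 110000 nM, and the step of a 1.7-fold higher number from compound 1 to compound 3 (0.23 log units; within the scatter) stays within the scatter. Compound 2 `O=C1C(O)=C(C(c2ccc([N+](=O)[O-])cc2)c2c[nH]c3ccccc23)C(=O)c2ccccc21` reaches only a limit, > 200000 nM, so the limit of > 200000 nM in this assay, at which 1 of the 3 values shown sits, applies to it. The step of an at least 3.0-fold higher number from compound 1 to compound 2 (0.48 log units; beyond the scatter) and the step of an at least 1.8-fold lower number from compound 2 to compound 3 (0.25 log units; that floor lies within the scatter) are therefore open-ended on the side of compound 2. Compound 4 `O=C1C(O)=C(C(c2ccc([N+](=O)[O-])cc2)c2c(-c3ccccc3)[nH]c3ccccc23)C(=O)c2ccccc21` differs from compound 2 by phenyl in place of hydrogen on an aromatic carbon. Among the compounds with values here, none of the measured steps touches that position; all three alter the aryl group on the chain carbon, so they give no direct guide for this change. With compound 2 at a limit, compound 4 is expected to remain near it, step a number no higher from compound 2 to compound 4 (the limit leaves the size open). The estimate for compound 4 is 200000 nM, range 60000 nM to 600000 nM.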

Compound 4, half-maximal inhibitory concentration: 14200 nM
The estimate for compound 4 lay 14-fold (1.15 log units) above the measured number, and the stated range ends above it.
By their numbers in this assay, from the lowest: compound 4; then compounds 1 and 3 (each within the scatter of the next). At a limit, above all of these: compound 2.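

In this assay, phenyl in place of hydrogen on the aromatic carbon next to the ring nitrogen gives an at least 14-fold lower number from compound 2 to compound 4 (1.14 log units; beyond the scatter), the first measured change away from the aryl group on the chain carbon. This position is therefore not silent: a change here takes the nitro compound from a limit to a measured number. Compound 2 stands at a limit, so the step is a floor and its full size stays open: the limit of > 200000 nM in this assay, at which 1 of the 4 values shown sits.

The compounds shown leave open whether phenyl lowers the number likewise with 4-fluorophenyl or 3-methoxyphenyl on the chain carbon. Also open, as far as these compounds go, is whether a methyl group or an amine on this carbon gives a step of similar size.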